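The source may report more compounds than this note shows. Statements on the series, on what has been measured and on what is new or still open speak of the compounds shown alone.

Measured in a functional assay on BaF3 cells (Mus musculus) for inhibition, read by MTT assay, with a stated time of 3 days; a lower number here means a stronger inhibitor of growth, a higher number a weaker inhibitor of growth:
- Compound 1 `O=C(Nc1ccc(Cl)cc1)Nc1ccc(Nc2ncnc3c2OCCN3)cc1`: > 10000 nM (a limit, not a number)
- Compound 2 `O=C(Nc1ccc(Nc2ncnc3c2OCCN3)cc1)Nc1ccc(C(F)(F)F)cc1`: 10000 nM

Going by the values given here, compound 2 gives the only actual number so far, 10000 nM. Compound 1 stands at a limit of the assay, > 10000 nM. That leaves the limit of > 10000 nM in this assay, at which 1 of the 2 values shown sits, as the whole of the evidence at that end, and no ranking of the two can be sized.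

The next compound is compound 3 `Cc1ccc(F)c(NC(=O)Nc2ccc(Nc3ncnc4c3OCCN4)cc2)c1`. The change is 2-fluoro-5-methylphenyl in place of 4-(trifluoromethyl)phenyl on an amide-type nitrogen.

Among the compounds with values here, only one measured step bears on this, a number no higher from compound 1 to compound 2 (the limit leaves the size open). It is a different exchange, on an aromatic carbon, and it has no readable size, so it gives only weak guidance. Nothing measured points to a clear move in this assay, so no step beyond the scatter is expected, and a result reported only as a limit would be no surprise. The expected step is a 1.7-fold lower number from compound 2 to compound 3 (0.22 log units; within the scatter).

For compound 3 the estimated value is 6000 nM, with an expected range of 800 nM to 15000 nM.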

Compound 3, concentration for 50% growth inhibition: > 10000 nM
Compound 3: a limit, no number (the forecaster's own chance of this, stated with the estimate: 45%); at least 1.6-fold (0.22 log units) between middle value and limit.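

In this assay compound 3 gives > 10000 nM, which is a limit of the assay and not a number. With 2-fluoro-5-methylphenyl in place of 4-(trifluoromethyl)phenyl on an amide-type nitrogen, the record shows a number no lower from compound 2 to compound 3 (the limit leaves the size open), while the remaining new step joins two limits and cannot be read. The three aromatic groups shown at this place have not moved the series away from the top of the measurable range, and this extends that picture from changes of a single group on the ring to a different set of groups on it: the limit of > 10000 nM in this assay, at which 2 of the 3 values shown sit.

Going by these compounds alone, with compound 2 at 10000 nM as the only number, the series offers no readable measure of how far a change at this place can shift growth inhibition. Still open, on these data alone, is whether a dimethylamine or a carboxylic acid on the aromatic ring, or a longer alkyl chain in place of that ring, would bring a value clear of that limit.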